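From a Tetrazole Amide to an Aminopyrrolidine Amide

This account rests on a few compounds, and the source may have more. Where it says the series, first, only, none or still open, it means among the compounds named here.

Measured so far:
compound 1 `NCc1cc(Oc2cccc(Oc3ccccc3)c2)nc(C(F)(F)F)c1` — "not determined" (no result reported)
compound 2 `NCc1cc(Oc2cccc(C(=O)NCc3cc4ccccc4s3)c2)nc(C(F)(F)F)c1` — "not determined" (no result reported)
compound 3 `NCc1cc(Oc2cccc(C(=O)NCCn3cnnn3)c2)nc(C(F)(F)F)c1` — 1990 nM

Going by the values given here, in an ADME assay on the whole organism (plasma, Mus musculus) for pharmacokinetics, read by LC-MS, at a dose of 30 mg/kg by the oral route (on this read-out higher numbers stand for higher exposure at the dose given and lower numbers for lower exposure), compound 3 gives 1990 nM, and it is the only compound here with a number, since compound 1 and compound 2 have no result. Compound 4 `NCc1cc(Oc2cccc(C(=O)N3CC[C@@H](N)C3)c2)nc(C(F)(F)F)c1` has not yet been measured. It differs from compound 3 in one place: a group of 6 heavy atoms (4 carbon, 2 nitrogen; one five-membered non-aromatic ring with 1 hetero atom) in place of a group of 8 heavy atoms (3 carbon, 5 nitrogen; one five-membered aromatic ring with 4 hetero atoms), on a carbonyl carbon. Among the compounds with values here, no measured pair shows how such a change moves the read-out, so the expectation rests on compound 3 alone. The step is expected to be small, within the usual scatter and in no firm direction, meaning a 1.3-fold lower number from compound 3 to compound 4 (0.12 log units; within the scatter). Compound 4 is therefore estimated at 1500 nM, with a range from 400 nM to 6000 nM.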

Compound 4, maximal plasma concentration: 670 nM
Estimate against measurement, compound 4: 2.2-fold (0.35 log units) above; the range from low to high includes it.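

In this assay, going by these compounds alone, the first readable step at this position is a 3.0-fold lower number from compound 3 to compound 4 (0.47 log units; beyond the scatter) on putting 3-aminopyrrolidin-1-yl on the carbonyl carbon in place of the group with the five-membered aromatic ring. This single pair shows that the group on this carbonyl carbon can move oral exposure beyond the usual scatter. No measurement shown here accounts for the drop.

The compounds shown leave open whether the ring or its amine matters more, as a plain pyrrolidin-1-yl or an open-chain aminoethyl amide would test. Going by these compounds, the opposite configuration at the stereocentre also stays open.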